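Cytotoxicity of a difluorobenzyl analogue in the CCRF-CEM assay

The source may report more compounds than this note shows. Statements on the series, on what has been measured and on what is new or still open speak of the compounds shown alone.

Compound 1 `O=c1ccn(C2C=CC(O)C2)c(=O)n1Cc1ccccc1`: > 250000 nM
Compound 2 `Cc1cc(=O)n(Cc2ccccc2)c(=O)n1C1C=CC(OC(=O)c2ccccc2)C1`: 34000 nM
Compound 3 `O=C(OC1C=CC(n2ccc(=O)n(Cc3ccccc3)c2=O)C1)c1ccccc1`: > 25000 nM

In an ADME assay on CCRF-CEM cells (Homo sapiens) for cytotoxicity, with a stated time of 3 days (on this read-out lower numbers stand for higher toxicity in this test and higher numbers for lower toxicity in this test), compound 1 reaches only a limit of the assay, > 250000 nM. Compound 2 gives a number in this assay, 34000 nM. Compound 3 again reaches only a limit, > 25000 nM, so its place is known only as a bound. The step that the two limits leave unreadable from compound 1 to compound 3 and the step that the limit leaves unreadable from compound 2 to compound 3 both remain unreadable, as the limit of > 25000 nM in this assay, at which 1 of the 3 values shown sits, and the limit of > 250000 nM in this assay, at which 1 of the 3 values shown sits, show. Compound 4 `O=C(OC1C=CC(n2ccc(=O)n(Cc3cc(F)cc(F)c3)c2=O)C1)c1ccccc1` differs from compound 3 by 3,5-difluorophenyl in place of phenyl on a saturated chain carbon bound to an aromatic nitrogen. For the measured compounds named here, no measured step touches this change, so no direction beyond the scatter is expected. Compound 4 is therefore expected near 40000 nM, within 12000 nM to 250000 nM, an expected step that the limit leaves unreadable from compound 3 to compound 4.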

Compound 4, half-maximal cytotoxic concentration: 32000 nM
Beside the measured number, compound 4's estimate is 1.3-fold (0.10 log units) above it; the range from low to high includes it.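

For the compounds shown here, compound 3 gives only a limit of the assay, > 25000 nM, so no step from it to compound 4 can be read. The compounds shown leave open whether benzyl to 3,5-difluorobenzyl shifts the read-out in this assay at all.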